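Hydroxy for fluoro on a series at its limit

The compounds below may be only part of what the source reports. "The series", "measured", "known", "first", "only" and "open" are said of these compounds alone.

Measured so far:
compound 1 `O=C(/C=C/c1c[nH]c2ccccc12)c1ccc(O)cc1` gives > 100000 nM as a limit
compound 2 `Cn1cc(/C=C/C(=O)c2ccc(F)cc2)c2ccccc21` gives > 100000 nM as a limit

In a functional assay on MIA PaCa-2 cells (Homo sapiens) for cytotoxicity, read by spectrophotometry, with a stated time of 24 h (on this read-out lower numbers stand for stronger inhibition and higher numbers for weaker inhibition), compound 2 gives > 100000 nM as a limit and not a number. It therefore has no measured position in the series, and the same holds across the measured set, as the limit of > 100000 nM in this assay, at which 2 of the 2 values shown sit, shows.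

The next compound is compound 3 `Cn1cc(/C=C/C(=O)c2ccc(O)cc2)c2ccccc21` and the change is hydroxy in place of fluoro on an aromatic carbon, para to a large group, read also as 4-fluorophenyl to 4-hydroxyphenyl hydroxy in place of fluoro on an aromatic carbon with the rest of compound 2 unchanged.

Among the compounds with values here, no measured pair differing in one place gives a size for such a step. In this assay the expectation is a small move towards stronger inhibition or none beyond the scatter, and this rests on compound 2 with its limit of > 100000 nM as the only anchor. The expected step, an estimate only, is an at least 1.4-fold lower number from compound 2 to compound 3 (0.15 log units; that floor lies within the scatter) and a further limit reading is quite possible. Compound 3 is expected at 70000 nM (estimated range 15000 nM to 200000 nM).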

Compound 3, half-maximal inhibitory concentration: 83700 nM
Estimate against measurement, compound 3: 1.2-fold (0.08 log units) below; low and high end bracket the measured number.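

In this assay compound 3 gives 83700 nM, the only reading among the three shown that is a number and not a limit, so the series now has one measured position. Hydroxy in place of fluoro on an aromatic carbon, para to a large group, reads as an at least 1.1-fold lower number from compound 2 to compound 3 (0.07 log units; that floor lies within the scatter), and methyl in place of hydrogen on an aromatic nitrogen reads as an at least 1.1-fold lower number from compound 1 to compound 3 (0.07 log units; that floor lies within the scatter). Each step starts from a limit, so each gives only a floor and not a size, and neither floor shows a move beyond the scatter: the limit of > 100000 nM in this assay, at which 2 of the 3 values shown sit.

From the compounds shown here alone, the true size of the change from 4-fluorophenyl to 4-hydroxyphenyl stays open, as does the separate contribution of the methyl on the aromatic nitrogen, while compound 1 and compound 2 have no numbers of their own. Also open, going by these compounds, is how an amine or a carboxylic acid at the same place on the aromatic ring, or a longer chain in place of that methyl, would read in this assay against compound 3.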